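One Stereocentre Inverted: From Compound 2 to Compound 4

The source may report more compounds than this note shows. Statements on the series, on what has been measured and on what is new or still open speak of the compounds shown alone.

Of the compounds shown here, three have so far been tested in an ADME assay on MT4 cells (Homo sapiens) for cytotoxicity, read by XTT assay, with a stated time of 5 days; on this read-out higher numbers stand for lower toxicity in this test and lower numbers for higher toxicity in this test. Compound 1 `COC(=O)N[C@H](C(=O)NN(CCC[C@@]1(O)Cc2ccc(cc2)/C=C\CNC(=O)[C@H](C(C)(C)C)NC1=O)Cc1ccc(Br)cc1)C(C)(C)C` gives 40000 nM and compound 2 `C=CCNC(=O)[C@@H](NC(=O)[C@@](O)(CCCN(Cc1ccc(Br)cc1)NC(=O)[C@@H](NC(=O)OC)C(C)(C)C)Cc1ccc(Br)cc1)C(C)C` gives 22000 nM and these two numbers lie within the usual scatter of each other. Compound 3 `C=CCNC(=O)[C@@H](NC(=O)[C@@](O)(CCCN(Cc1ccc(Br)cc1)NC(=O)[C@@H](NC(=O)OC)C(C)(C)C)Cc1ccc(CC=C)cc1)C(C)(C)C` gives > 50000 nM as a limit of the assay and not as a number. Compound 2 therefore stands level with compound 1 on the numbers available, with nothing separating them beyond the scatter.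

Compound 4 `C=CCNC(=O)[C@@H](NC(=O)[C@](O)(CCCN(Cc1ccc(Br)cc1)NC(=O)[C@@H](NC(=O)OC)C(C)(C)C)Cc1ccc(Br)cc1)C(C)C` has not yet been measured. It has the same atoms and bonds as compound 2 and differs only in configuration as drawn (the two compounds have the same atoms and bonds and differ only in configuration as drawn: 1 of 3 stereo elements differ; a stereocentre at a saturated chain carbon is drawn R in compound 2 and S in compound 4) since a stereocentre at a saturated chain carbon is drawn R in compound 2 and S in compound 4. Among the compounds with values here, no pair of measured compounds shows what such an inversion does in this assay and so no direction is favoured. The expectation rests on compound 2 at 22000 nM and on compound 1 at 40000 nM as the nearest numbers. The estimated step of a 1.2-fold higher number from compound 2 to compound 4 (0.07 log units; within the scatter) is expected to stay within the scatter. For compound 4 the expected value is 26000 nM with an estimated range from 12000 nM to 50000 nM in this test.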

Compound 4, half-maximal cytotoxic concentration: 4500 nM
Beside the measured number, compound 4's estimate is 5.8-fold (0.76 log units) above it, outside the stated range (below it).
By their numbers in this assay, from the lowest: compound 4; then compounds 2 and 1 (each within the scatter of the next). At a limit, above all of these: compound 3.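

In this assay, inverting the stereocentre at a saturated chain carbon, drawn R in compound 2 and S in compound 4, gives a 4.9-fold lower number from compound 2 to compound 4 (0.69 log units; beyond the scatter). The earlier compounds shown here offered no pair in which configuration alone changed, so they could not show that this position responds to inversion in this test. The step can be ascribed to the inversion at this one carbon, and to nothing else in the structures, because of a single plain fact: the fact that compounds 2 and 4 differ only in the configuration as drawn.

What the compounds shown leave open is whether the same inversion would move the number in the same direction and by a similar size in compound 1 or compound 3, whose structures differ from compound 2 elsewhere, and a single pair cannot settle that. From the compounds shown here alone, it also remains open whether an amine at this stereocentre would keep the same difference between the R and S forms, or whether the difference is particular to the groups present in compound 2 and compound 4.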